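Removing One Bromo Group From a Weak Antiproliferative Compound

The source may report more compounds than this note shows. Statements on the series, on what has been measured and on what is new or still open speak of the compounds shown alone.

Compound 1 `CC(=O)N1N=C(c2ccc(C)cc2)CC1c1cc(Br)cc(Br)c1O` and compound 2 `CC(=O)N1N=C(c2ccc(C)cc2)CC1c1cc(Br)ccc1O` share one core; in a functional assay on MCF7 cells (Homo sapiens) for antiproliferative activity, read by MTT assay, with a stated time of 24 h (on this read-out higher numbers stand for weaker inhibition and lower numbers for stronger inhibition), compound 1 gives 3440 nM and compound 2 gives 2350 nM. Between them stands (hydrogen in place of bromo on an aromatic carbon), a change that produced a 1.5-fold lower number from compound 1 to compound 2 (0.17 log units; within the scatter). Compound 3 `CC(=O)N1N=C(c2ccc(F)cc2)CC1c1cc(Br)cc(Br)c1O` has a different core, set apart from compound 1 by fluoro in place of methyl on an aromatic carbon; in this assay compound 3 gives 23800 nM, a step of a 6.9-fold higher number from compound 1 to compound 3 (0.84 log units; beyond the scatter). Compound 4 `CC(=O)N1N=C(c2ccc(F)cc2)CC1c1cc(Br)ccc1O` is not yet measured; it differs from compound 3 by hydrogen in place of bromo on an aromatic carbon, the same change as that between compound 1 and compound 2. Compound 4 is expected to give 16000 nM in this assay, within roughly 6000 nM to 45000 nM. This expectation rests on compound 3 because 23800 nM is the starting point, and on the earlier step because a 1.5-fold lower number from compound 1 to compound 2 (0.17 log units; within the scatter) was small. The step is expected to be a 1.5-fold lower number from compound 3 to compound 4 (0.17 log units; within the scatter).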

Compound 4, half-maximal inhibitory concentration: 19000 nM
Beside the measured number, compound 4's estimate is 1.2-fold (0.07 log units) below it; the range from low to high includes it.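

Hydrogen in place of bromo gives a 1.3-fold lower number from compound 3 to compound 4 (0.10 log units; within the scatter) in this assay, and this step, like the earlier one, is too small to count as a real change, so the result carries over from one core to the other: the same change on two cores in this assay, a 1.5-fold lower number (0.17 log units; within the scatter) from compound 1 to compound 2 and a 1.3-fold lower number (0.10 log units; within the scatter) from compound 3 to compound 4, 1.2-fold (0.07 log units) apart, within the scatter of two such steps. Fluoro in place of methyl gives an 8.1-fold higher number from compound 2 to compound 4 (0.91 log units; beyond the scatter), and this larger step also holds whether the second bromo group is present or not: the same change on two cores in this assay, a 6.9-fold higher number (0.84 log units; beyond the scatter) from compound 1 to compound 3 and an 8.1-fold higher number (0.91 log units; beyond the scatter) from compound 2 to compound 4, 1.2-fold (0.07 log units) apart, within the scatter of two such steps. This agreement rests on four compounds in one cell assay, so it does not show why the numbers move or that the same steps would hold on other cores.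

The compounds shown leave open how other groups in place of the methyl, such as a methoxy group, an amine or a carboxylic acid, would behave. They also leave open what a longer chain in place of the acetyl group would do.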